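The source may hold more compounds than are shown below. What is called first, only, known or untested is meant among the compounds shown, and "the series" means these compounds.

Measured compounds so far:

Compound 1, `Cc1ccc(S(=O)(=O)Cc2ccccc2)cc1C#Cc1cc(Cl)ccc1OCC(=O)O`, gives 5 nM in an assay on CHO cells for displacement of a labelled ligand from prostaglandin D2 receptor 2 (Homo sapiens), read by scintillation counting; a lower number here means a stronger inhibitor, a higher number a weaker inhibitor.
Compound 2, `CN(C)C(=O)c1cccc(C#Cc2cc(Cl)ccc2OCC(=O)O)c1`, gives 52 nM in this assay.

Both compounds share the same core and differ only in the group carried on the outer aromatic ring. Compound 2 stands at the higher of the two numbers: its nearest neighbour is compound 1, whose number is lower by a margin well beyond the usual scatter of repeated measurements, so compound 1 is the stronger binder of the pair. Among the compounds with values here, no single-point step between measured compounds has been recorded, so the only comparison available is this one.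

Compound 3, `CS(=O)(=O)c1cccc(C#Cc2cc(Cl)ccc2OCC(=O)O)c1`, is yet to be measured. It differs from compound 2 in one place: methylsulfonyl in place of dimethylcarbamoyl on an aromatic carbon. The group that enters is of the same kind as the sulfonyl that compound 1 carries, though smaller. Given that compound 1 gives 5 nM, a move toward a lower number in this assay seems more likely than none, but the evidence rests on two compounds only. The step from compound 2 to compound 3 is expected to be a 2.1-fold lower number from compound 2 to compound 3 (0.32 log units; beyond the scatter). Compound 3 is expected to give about 25 nM, within a range from 8 nM to 80 nM.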

Compound 3, inhibition constant: 15 nM
Compound 3: the middle estimate sits 1.7-fold (0.22 log units) above what was measured, within the range that was stated.
By their numbers in this assay, from the lowest: compound 1; then compound 3; then compound 2.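

In this assay, within the data shown here, replacing dimethylcarbamoyl with methylsulfonyl on this aromatic carbon, meta to a large group, gives a 3.5-fold lower number from compound 2 to compound 3 (0.54 log units; beyond the scatter) and provides the first comparison in which only one place changes. The step is modest but beyond the scatter, so this position is not indifferent to the group it carries, even though neither group has a ring or a hydrogen-bond donor. The entering group has fewer heavy atoms and more hydrogen-bond acceptors, but no measurement here shows whether either difference accounts for the change.

A single pair cannot show whether the lower number belongs to methylsulfonyl specifically, or whether a nitrile, an amine, a carboxylic acid or a longer chain such as ethylsulfonyl at this place would give a similar result. Compound 1 also carries a sulfonyl but differs from compound 3 in more than one place, so the value of compound 1, 5 nM, does not show how much of its stronger binding comes from that group.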